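The source may report more compounds than this note shows. Statements on the series, on what has been measured and on what is new or still open speak of the compounds shown alone.

Compound 1 `Cc1cccc(/C=C2\SC(=S)N(NS(=O)(=O)c3ccccc3)C2=O)c1` is the reference point of the set. In a functional assay on HFF cells (Homo sapiens) for cytotoxicity (a lower number here means a stronger inhibitor, a higher number a weaker inhibitor), compound 1 gives > 100000 nM, which is a limit of the assay and not a number. Compound 2 `COc1cccc(/C=C2\SC(=S)N(NS(=O)(=O)c3ccccc3)C2=O)c1` gives > 100000 nM in this assay, again a limit. Compound 3 `O=C1/C(=C/c2ccc(F)cc2F)SC(=S)N1NS(=O)(=O)c1ccccc1` gives > 100000 nM in this assay, also a limit. The steps between these three are therefore unreadable: a step that the two limits leave unreadable from compound 1 to compound 2, a step that the two limits leave unreadable from compound 1 to compound 3 and a step that the two limits leave unreadable from compound 2 to compound 3. Among the compounds with values here, all values sit at one point, (the limit of > 100000 nM in this assay, at which 3 of the 3 values shown sit), so compound 1 stands at that limit with no measured step above or below it to place it.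

Compound 4 `O=C1/C(=C/c2ccc(F)c(F)c2F)SC(=S)N1NS(=O)(=O)c1ccccc1` differs from compound 1 at one place: 2,3,4-trifluorophenyl in place of 3-methylphenyl on a double-bonded chain carbon bound to a double-bonded ring carbon The measured steps bearing on this change are those into compound 3, which also replaces the 3-methylphenyl of compound 1 and the 3-methoxyphenyl of compound 2, and neither gives a size. With every value a limit, no direction can be read; the expectation is that compound 4 stays at the limit too, the step of a number no higher from compound 1 to compound 4 (the limit leaves the size open) expected to be none beyond the scatter. The estimated value for compound 4 is 100000 nM, within 30000 nM to 300000 nM.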

Compound 4, half-maximal inhibitory concentration: > 100000 nM
Compound 4: a limit, no number (the forecaster's own chance of this, stated with the estimate: 85%); the middle value lies on the limit itself.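

The steps from compound 1, compound 2 and compound 3 to compound 4 cannot be read in this assay, each value being a limit of the assay and not a number: the limit of > 100000 nM in this assay, at which 4 of the 4 values shown sit.

The compounds shown leave open whether any replacement on the double-bonded chain carbon gives a measurable value, and how far apart these four compounds lie.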